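Linker double-bond geometry in the alkynyl uracil phthalimide series

This account rests on a few compounds, and the source may have more. Where it says the series, first, only, none or still open, it means among the compounds named here.

Measured so far in a functional assay on CCRF-CEM cells (Homo sapiens) for antiproliferative activity, read by MTT assay, with a stated time of 3 days; a lower number here means a stronger inhibitor, a higher number a weaker inhibitor:
compound 1, `CCCCCCCCC#Cc1cn(C/C=C\CN2C(=O)c3ccccc3C2=O)c(=O)[nH]c1=O`: 39000 nM
compound 2, `CCCCCCCCC#Cc1cn(C/C=C/CN2C(=O)c3ccccc3C2=O)c(=O)[nH]c1=O`: compound 2 reaches only a limit of the assay, > 250000 nM
compound 3, `CCCCCc1ccc(C#Cc2cn(C/C=C\CN3C(=O)c4ccccc4C3=O)c(=O)[nH]c2=O)cc1`: 102000 nM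

Of the two plain numbers, compound 3 is the higher one, separated from its nearest neighbour by a 2.6-fold higher number from compound 1 to compound 3 (0.42 log units; beyond the scatter). The third entry, for compound 2, is a limit.

Compound 4, `CCCCCc1ccc(C#Cc2cn(C/C=C/CN3C(=O)c4ccccc4C3=O)c(=O)[nH]c2=O)cc1`, is not yet measured. Relative to compound 3, (the two compounds have the same atoms and bonds and differ only in configuration as drawn: 1 of 1 stereo elements differ; a double bond is drawn Z in compound 3 and E in compound 4). For the measured compounds named here, the one measured step that bears on this change is an at least 6.4-fold higher number from compound 1 to compound 2 (0.80 log units; beyond the scatter), since the fact that compounds 1 and 2 differ only in the configuration as drawn makes it the same alteration on the octyl analogue. A step of at least that size, in the same direction, is expected here.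

For compound 4 the expected step is a 4.9-fold higher number from compound 3 to compound 4 (0.69 log units; beyond the scatter), giving an estimate of 500000 nM in this assay with a range from 150000 nM to 2000000 nM. Given (the limit of > 250000 nM in this assay, at which 1 of the 3 values shown sits), the result for compound 4 may well be reported only as a limit.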

Compound 4, half-maximal inhibitory concentration: 23000 nM
Estimate against measurement, compound 4: 22-fold (1.34 log units) above; measured number below the stated range.
By their numbers in this assay, from the lowest: compounds 4 and 1 (each within the scatter of the next); then compound 3. At a limit, above all of these: compound 2.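

In this assay the linker geometry has no single direction across the series: on the 4-pentylphenyl side, E in place of Z gives a 4.4-fold lower number from compound 3 to compound 4 (0.65 log units; beyond the scatter), opposite to the direction running from compound 1 to compound 2. The group on the triple-bonded carbon also counts for more with E geometry, with an at least 10-fold lower number from compound 2 to compound 4 (1.03 log units; beyond the scatter). The two changes therefore do not act independently: the same change on two cores in this assay, a 2.6-fold higher number (0.42 log units; beyond the scatter) from compound 1 to compound 3 and an at least 10-fold lower number (1.03 log units; beyond the scatter) from compound 2 to compound 4, at least 28-fold (1.45 log units) apart, beyond the scatter of two such steps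

Still open, going by these compounds, is whether this reversal holds for other groups on the triple-bonded carbon, such as a longer chain or a 4-methoxyphenyl group.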